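The compounds below may be only part of what the source reports. "The series", "measured", "known", "first", "only" and "open" are said of these compounds alone.

Two members of the series have numbers in an assay on isolated protein for displacement of a labelled ligand from Motilin receptor (Homo sapiens); a lower number here means a stronger inhibitor, a higher number a weaker inhibitor. Compound 1 `CCC[C@@H]1NC(=O)[C@@H](C(C)C)NC(=O)[C@@H](CCc2ccccc2)NCCOc2ccccc2CCCNC1=O` gives 1490 nM in this assay. Compound 2 `CCC[C@@H]1NC(=O)[C@@H](C(C)C)NC(=O)[C@@H](Cc2c[nH]c3ccccc23)NCCOc2ccccc2CCCNC1=O` gives 255 nM in this assay. Among the compounds with values here, the single step measured so far, a 5.8-fold lower number from compound 1 to compound 2 (0.77 log units; beyond the scatter), shows that the group on the saturated chain carbon bound to a saturated ring carbon is a place where the number moves. Compound 2 thus stands with the lowest of the two numbers in this assay, its nearest neighbour being compound 1.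

Compound 3 `CCC[C@@H]1NC(=O)[C@@H](C(C)C)NC(=O)[C@@H](Cc2csc3ccccc23)NCCOc2ccccc2CCCNC1=O` carries 1-benzothiophen-3-yl in place of 1H-indol-3-yl on a saturated chain carbon bound to a saturated ring carbon. Within the data shown here, no measured step covers an exchange of a hydrogen-bond donor for a hydrogen-bond acceptor at this place; the one step that touches the position, a 5.8-fold lower number from compound 1 to compound 2 (0.77 log units; beyond the scatter), shows only that what sits here matters, and it ran toward lower numbers when the 1H-indol-3-yl group entered. With the two fused aromatic rings kept and the donor gone, the number for compound 3 is expected to rise somewhat, by about a 2.0-fold higher number from compound 2 to compound 3 (0.29 log units; within the scatter), though a result within the scatter would not be surprising. Compound 3 is therefore estimated at 500 nM in this assay, in the range 150 nM to 2000 nM.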

Compound 3, inhibition constant: 11 nM
Beside the measured number, compound 3's estimate is 45-fold (1.66 log units) above it; the measured number lies below the stated range.
By their numbers in this assay, from the lowest: compound 3; then compound 2; then compound 1.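

At the saturated chain carbon bound to a saturated ring carbon, 1-benzothiophen-3-yl in place of 1H-indol-3-yl gives a 23-fold lower number from compound 2 to compound 3 (1.37 log units; beyond the scatter) in this assay, so two groups with the same heavy-atom count and the same ring types are far from interchangeable here, and the hydrogen-bond donor of 1H-indol-3-yl is not required for a low number in this series. This step is larger than the earlier 5.8-fold lower number from compound 1 to compound 2 (0.77 log units; beyond the scatter), and the whole span from benzyl to 1-benzothiophen-3-yl at this place, a 140-fold lower number from compound 1 to compound 3 (2.13 log units; beyond the scatter), shows the position to be much more sensitive than the first pair indicated. Nothing available explains why the exchange of nitrogen for sulfur in the five-membered ring has so large an effect on the number.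

The compounds shown leave open whether a benzofuran-3-yl group, with oxygen in that ring, or a naphthalen-1-yl group, with no hetero atom, would stand nearer to compound 3 or to compound 2. Also open, going by these compounds, is whether the low number of compound 3 survives an amine or a carboxylic acid on the six-membered aromatic ring of the 1-benzothiophen-3-yl group.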